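This account rests on a few compounds, and the source may have more. Where it says the series, first, only, none or still open, it means among the compounds named here.

Of the compounds shown here, three that share one core have been measured in a functional assay on TM4 cells (Mus musculus) for cytotoxicity, read by MTT assay, with a stated time of 72 h; on this read-out lower numbers stand for stronger inhibition and higher numbers for weaker inhibition. There compound 1 `Nc1nc(NC2CCCCC2)sc1C(=O)c1ccccc1` gives 9300 nM, compound 2 `Nc1nc(Nc2ccccc2)sc1C(=O)c1cccnc1` gives 5500 nM and compound 3 `Nc1nc(Nc2ccccc2)sc1C(=O)c1ccc(F)cc1` gives 14000 nM. Compound 3 thus lies within the usual scatter of compound 1, but clearly apart from compound 2.

Compound 4 `Nc1nc(Nc2ccccc2)sc1C(=O)c1cccc(F)c1` has not yet been measured. Its difference from compound 3 is 3-fluorophenyl in place of 4-fluorophenyl on a carbonyl carbon, so the two have the same atoms, joined differently.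

Among the compounds with values here, the only measured step at that carbonyl carbon, a 2.5-fold higher number from compound 2 to compound 3 (0.41 log units; beyond the scatter), exchanged pyridin-3-yl for 4-fluorophenyl and stayed modest. Within the data shown here, no measured pair shows the fluorine changing place, so the evidence is thin, but a smaller step is expected here. The expected change is a 1.2-fold lower number from compound 3 to compound 4 (0.07 log units; within the scatter), with none beyond the scatter foreseen in this assay. For compound 4 the estimated value is 12000 nM, with an expected range from 6000 nM to 24000 nM.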

Compound 4, half-maximal inhibitory concentration: 5100 nM
For compound 4 the middle estimate is 2.4-fold (0.37 log units) above the measured one; measured number below the stated range.
By their numbers in this assay, from the lowest: compounds 4, 2, 1 and 3 (each within the scatter of the next, the first and the last beyond it).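

Moving the fluorine alone changes the result in this assay: with the same atoms, 3-fluorophenyl in place of 4-fluorophenyl gives a 2.7-fold lower number from compound 3 to compound 4 (0.44 log units; beyond the scatter), so this position on the carbonyl carbon responds to where the fluorine sits, not only to which ring is attached. The 3-fluorophenyl and pyridin-3-yl groups, by contrast, cannot be told apart here, with a 1.1-fold lower number from compound 2 to compound 4 (0.03 log units; within the scatter) on exchanging one for the other. Nothing available explains why the place of the fluorine matters.

Still open, on these data alone, is whether a chlorine atom or a methoxy group on this phenyl ring, in place of the fluorine, would show the same dependence on place. As far as these compounds go, it is also open whether the fluorine shift would have the same size with the cyclohexyl group of compound 1 on the amine.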